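Adding a Second Trifluoromethyl to the Methoxy Benzanilide

The source may report more compounds than this note shows. Statements on the series, on what has been measured and on what is new or still open speak of the compounds shown alone.

Within the data shown here, in an ADME assay on RAW264.7 cells (Mus musculus) for cytotoxicity, read by MTT assay, with a stated time of 48 h (on this read-out lower numbers stand for stronger inhibition and higher numbers for weaker inhibition), compound 2 `COc1cc(NC(=O)c2cccc(C(F)(F)F)c2)ccc1NS(C)(=O)=O` gives 84800 nM and stands as the only number among the values shown. Compound 1 `Cc1cc(NC(=O)c2cc(C(F)(F)F)cc(C(F)(F)F)c2)ccc1NS(C)(=O)=O` reaches only the limit of this assay at > 250000 nM and no number. Compound 3 `COc1cc(NC(=O)c2cc(C(F)(F)F)cc(C(F)(F)F)c2)ccc1NS(C)(=O)=O` differs from compound 2 by trifluoromethyl in place of hydrogen on an aromatic carbon. No measured step of this kind is shown, so the step of a 1.8-fold higher number from compound 2 to compound 3 (0.25 log units; within the scatter) is expected to be small, toward weaker inhibition if anything. Compound 3 is therefore estimated at 150000 nM in this assay, within a range from 50000 nM to 400000 nM, and it may well come back only as a limit.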

Compound 3, half-maximal inhibitory concentration: > 250000 nM
Compound 3 was reported as a limit (the forecaster's own chance of this, stated with the estimate: 50%); middle value at least 1.6-fold (0.22 log units) away from the limit.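

In this assay, among these compounds, trifluoromethyl in place of hydrogen on an aromatic carbon, meta to a trifluoromethyl group, gives an at least 2.9-fold higher number from compound 2 to compound 3 (0.46 log units; beyond the scatter), a first step at this place and one toward weaker inhibition. As far as these compounds go, compound 3 gives > 250000 nM, which is a limit and not a number, so the true size of the step stays open. The step from compound 1, methoxy in place of methyl on an aromatic carbon, cannot be read: the limit of > 250000 nM in this assay, at which 2 of the 3 values shown sit.

From the compounds shown here alone, it remains open whether a nitrile or an amine on this aromatic carbon would give a number within the range of the assay.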